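Thiophen-3-yl for thiophen-2-yl across two cores

The source may report more compounds than this note shows. Statements on the series, on what has been measured and on what is new or still open speak of the compounds shown alone.

Compound 1 `Clc1ccc(-c2cc(-c3ccoc3)cc(-c3cccs3)n2)cc1` and compound 2 `Clc1ccc(-c2cc(-c3ccoc3)cc(-c3ccsc3)n2)cc1` share one core; in a functional assay on HeLa cells (Homo sapiens) for cytotoxicity, in the presence of a further agent that is not named here (a higher number here means a weaker inhibitor, a lower number a stronger inhibitor), compound 1 gives 5530 nM and compound 2 gives 4140 nM. The change thiophen-3-yl in place of thiophen-2-yl on an aromatic carbon made a 1.3-fold lower number from compound 1 to compound 2 (0.13 log units; within the scatter). Compound 3 `Cc1ccc(-c2cc(-c3ccc(Cl)o3)cc(-c3cccs3)n2)cc1` carries a different core; the difference between the two cores is not broken down here. In this assay compound 3 gives 16300 nM, the highest of the three numbers. Compound 4 `Cc1ccc(-c2cc(-c3ccc(Cl)o3)cc(-c3ccsc3)n2)cc1` is not yet measured. The change thiophen-3-yl in place of thiophen-2-yl on an aromatic carbon is the same kind of change as that made between compound 1 and compound 2, not the same: here the place is meta to a 4-methylphenyl group and meta to a 5-chlorofuran-2-yl group, there meta to a 4-chlorophenyl group and meta to a furan-3-yl group. Because a 1.3-fold lower number from compound 1 to compound 2 (0.13 log units; within the scatter) stayed within the scatter, the step of a 1.2-fold lower number from compound 3 to compound 4 (0.08 log units; within the scatter) is expected to be similarly small. Compound 4 is estimated at 13500 nM, between 6500 nM and 28000 nM.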

Compound 4, half-maximal inhibitory concentration: 16200 nM
The estimate for compound 4 lay 1.2-fold (0.08 log units) below the measured number; low and high end bracket the measured number.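

In this assay, thiophen-3-yl in place of thiophen-2-yl made a 1.0-fold lower number from compound 3 to compound 4 (0.00 log units; within the scatter) on the second core. The two steps do not differ, so the swap carries over between these two cores: the same change on two cores in this assay, a 1.3-fold lower number (0.13 log units; within the scatter) from compound 1 to compound 2 and a 1.0-fold lower number (0.00 log units; within the scatter) from compound 3 to compound 4, 1.3-fold (0.12 log units) apart, within the scatter of two such steps.
Within the data shown here, only two pairs show this parallel, and neither step lies beyond the scatter. The data do not show that the swap would stay this small on every core in the series, nor do they say which of the core differences sets the gap between the two pairs.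

Still open, on these data alone, is whether an amine or a carboxylic acid in place of the thiophene ring would move the number. It is also open which single change between the cores accounts for their different values.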